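Changing the chain end of compound 3

The source may report more compounds than this note shows. Statements on the series, on what has been measured and on what is new or still open speak of the compounds shown alone.

Going by the values given here, in a functional assay on ECa-109 cells (Homo sapiens) for antiproliferative activity, read by MTT assay, with a stated time of 48 h (on this read-out lower numbers stand for stronger inhibition and higher numbers for weaker inhibition), compound 3 `Cn1cc(C2=C(c3nn(CCCN4CCCCC4)c4ncccc34)C(=O)NC2=O)c2ccccc21` gives 42300 nM, the only exact number so far. Compound 1 `Cn1cc(C2=C(c3nn(CCCn4cncn4)c4ncccc34)C(=O)NC2=O)c2ccccc21` gives only a limit of the assay, > 100000 nM. Compound 2 `CN1CCN(CCCn2nc(C3=C(c4cn(C)c5ccccc45)C(=O)NC3=O)c3cccnc32)CC1` also gives only a limit, > 100000 nM. Compound 4 `Cn1cc(C2=C(c3nn(CCCCn4ccnc4)c4ncccc34)C(=O)NC2=O)c2ccccc21` is unmeasured and differs from compound 3 by (1H-imidazol-1-yl)methyl in place of piperidin-1-yl on a saturated chain carbon, three bonds along the chain from an aromatic nitrogen: (1H-imidazol-1-yl)methyl replaces piperidin-1-yl on a saturated chain carbon. The closest guide is compound 1, whose chain also ends in a five-membered aromatic ring, with an at least 2.3-fold lower number from compound 1 to compound 3 (0.37 log units; beyond the scatter). Compound 2 adds an at least 2.3-fold lower number from compound 2 to compound 3 (0.37 log units; beyond the scatter). Both steps are only bounds, so a modest loss of activity in this assay is expected, meaning a higher number. The expected change is a 2.1-fold higher number from compound 3 to compound 4 (0.33 log units; beyond the scatter). The estimate for compound 4 is 90000 nM, with an expected range of 30000 nM to 250000 nM.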

Compound 4, half-maximal inhibitory concentration: 23500 nM
Compound 4: middle estimate off by 3.8-fold (0.58 log units), on the high side; the whole stated range lies above it.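

In this assay, there is a 1.8-fold lower number from compound 3 to compound 4 (0.26 log units; within the scatter), so the imidazole-ended butyl chain and the piperidine-ended propyl chain cannot be told apart. A five-membered aromatic ring at the chain end therefore does not by itself bring a compound to the limit, as compound 1 alone might have suggested. There is also an at least 4.2-fold lower number from compound 1 to compound 4 (0.62 log units; beyond the scatter) and an at least 4.2-fold lower number from compound 2 to compound 4 (0.62 log units; beyond the scatter), but both are only bounds: the limit of > 100000 nM in this assay, at which 2 of the 4 values shown sit.

Ring and chain length change together here, so their separate contributions remain open. A 3-(1H-imidazol-1-yl)propyl chain or a 4-(piperidin-1-yl)butyl chain would separate them.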